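A few compounds are considered here, and "the series" means these few. Any claim that something is new, unique, unknown or untested is made for them only; others in the source may bear on it.

The measured compounds in a functional assay on a cell-free system (plasma, Oryctolagus cuniculus) for inhibition, with stated times of 5 min, 1 min and 6 min; on this read-out lower numbers stand for stronger inhibition and higher numbers for weaker inhibition:

compound 1, `C=CCOn1c(-c2cccc(C#N)c2)nc(C)c1C(=O)OCC`, gives 5860 nM
compound 2, `CCOC(=O)c1c(C)nc(-c2cccc(C#N)c2)n1OCCCO`, gives 11400 nM
compound 3, `CCOC(=O)c1c(C)nc(-c2cccc(C#N)c2)n1OCc1ccc(Cl)cc1`, gives 6830 nM

Compound 1 holds the lowest of the three numbers, yet neither neighbour is set apart from it by more than the scatter: the nearest is compound 3, a 1.2-fold higher number from compound 1 to compound 3 (0.07 log units; within the scatter), and the furthest is compound 2, a 1.9-fold higher number from compound 1 to compound 2 (0.29 log units; within the scatter). Between the other two, a 1.7-fold lower number from compound 2 to compound 3 (0.22 log units; within the scatter). On this assay the three compounds are thus not told apart.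

Compound 4, `CCOC(=O)c1c(C)nc(-c2cccc(C#N)c2)n1OCc1ccc(OC)cc1`, has not yet been measured. Against compound 1 it shows (4-methoxyphenyl in place of vinyl on a saturated chain carbon bound to an oxygen on an aromatic ring). Among the measured compounds shown here, the step that bears most directly on it is the one to compound 3, where 4-chlorophenyl replaced vinyl on the same saturated chain carbon bound to an oxygen on the aromatic ring, and that step stayed within the scatter; the step to compound 2, with 2-hydroxyethyl in place of vinyl, did the same. With every change at this carbon so far leaving the number within the scatter, the expectation for compound 4 is a step of a 1.2-fold higher number from compound 1 to compound 4 (0.08 log units; within the scatter), that is, none beyond the scatter. The estimate for compound 4 in this assay is 7000 nM, within 3000 nM to 16000 nM.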

Compound 4, half-maximal inhibitory concentration: 6830 nM
The estimate for compound 4 lay 1.0-fold (0.01 log units) above the measured number, and the stated range covers the measured number.
By their numbers in this assay, from the lowest: compounds 1, 3, 4 and 2 (each within the scatter of the next).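

Methoxy in place of chloro on an aromatic carbon is a change on the aromatic ring itself, which the earlier compounds did not vary, and in this assay it gives no change at the digits printed from compound 3 to compound 4 (within the scatter). A third kind of group on the saturated chain carbon bound to an oxygen on an aromatic ring also fails to separate the compounds, with 4-methoxyphenyl in place of vinyl giving a 1.2-fold higher number from compound 1 to compound 4 (0.07 log units; within the scatter) and 4-methoxyphenyl in place of 2-hydroxyethyl giving a 1.7-fold lower number from compound 2 to compound 4 (0.22 log units; within the scatter). No measured evidence is available to explain these results.

The compounds shown leave open whether any group on this carbon, such as an amine, a carboxylic acid or a longer chain, would produce a step beyond the scatter. They also leave open whether a different group on the aromatic ring, such as a nitro group, would do so.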